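Removing the Hydroxy Group from a Binding Compound

This account rests on a few compounds, and the source may have more. Where it says the series, first, only, none or still open, it means among the compounds named here.

In an assay on cell membranes for displacement of a labelled ligand from metabotropic glutamate receptor 5 (Rattus norvegicus), tested at 1 uM (a higher number here means more inhibition at the concentration tested (going by the name of the read-out), a lower number less inhibition), three compounds have been measured. Compound 1 `O=C(CCc1ccc(F)cc1)c1[nH]c2ccccc2c1-c1ccc(F)cc1` gives 4%, compound 2 `OC(CCc1ccc(F)cc1)c1sc2ncccc2c1-c1ccc(F)cc1` gives 3%, and compound 3 `Fc1ccc(-c2nc(-c3sc4ncccc4c3-c3ccc(Cl)cc3)no2)cc1` gives 0%. Compound 2 stands second highest of these three numbers, with compound 1 nearest and compound 3 furthest, yet both gaps lie within the scatter, so all three show essentially the same low level of inhibition.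

Compound 4 `Fc1ccc(CCCc2sc3ncccc3c2-c2ccc(F)cc2)cc1` has not yet been measured. It differs from compound 2 by hydrogen in place of hydroxy on a saturated chain carbon bound to an aromatic carbon and a saturated chain carbon. Within the data shown here, no measured pair differs at a single place, so there is no step to lean on. Because compound 2 gives 3%, close to zero, the expected step is a number 1 percentage points higher from compound 2 to compound 4 (within the scatter), nothing beyond the scatter in either direction. Compound 4 is therefore estimated at 4%, ranging from -8% to 16%.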

Compound 4, a percentage reported as inhibition, at one concentration (the size of the read-out at that concentration, not a potency): 0%
For compound 4 the middle estimate is 4 percentage points above the measured one; low and high end bracket the measured number.
By their numbers in this assay, from the lowest: compounds 3, 4, 2 and 1 (each within the scatter of the next).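

Putting hydrogen in place of hydroxy on this saturated chain carbon gives a number 3 percentage points lower from compound 2 to compound 4 (within the scatter) in this assay. This first comparison of compounds that differ in one place shows inhibition staying at the same low level with or without the hydroxy, although readings this close to zero leave little room to see any effect of the group. No available measurement offers an explanation for this result.

Going by these compounds, whether an amine or a carboxylic acid on this same carbon would raise inhibition stays open. So does whether a longer chain would.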